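The compounds below may be only part of what the source reports. "The series", "measured", "known", "first", "only" and "open" are said of these compounds alone.

Measured in a functional assay on A2780 cells (Homo sapiens) for inhibition, with a stated time of 72 h (on this read-out higher numbers stand for weaker inhibition and lower numbers for stronger inhibition), so far:

Compound 1, `CC1(C)CCOc2ccc(NC(=O)Nc3ccc([N+](=O)[O-])cc3)cc21`: in this assay compound 1 gives 6700 nM.
Compound 2, `CCC1(CC)CC(C)(C)Oc2ccc(NC(=O)Nc3ccc(C(F)(F)F)cc3)cc21`: in this assay compound 2 gives 2430 nM.

On these two numbers compound 1 stands highest, and compound 2 sits at a lower number, by a gap that is beyond the usual scatter. Within the data shown here, no single-point step between the two measured compounds exists, since they differ in more than one place, so their values can only be set side by side.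

Compound 3, `CC1(C)CCOc2ccc(NC(=O)Nc3ccc(OC(F)(F)F)cc3)cc21`, has not been measured. It differs from compound 1 in one place: trifluoromethoxy in place of nitro on an aromatic carbon. The shared core of compound 1 is kept unchanged. Among the measured compounds shown here, there is no measured step of this kind to lean on. In this assay the step from compound 1 to compound 3 is expected to be modest, toward a lower number, and possibly not beyond the scatter, an expected 1.7-fold lower number from compound 1 to compound 3 (0.22 log units; within the scatter). On that basis compound 3 is estimated to give about 4000 nM in this assay, with a likely span from 1500 nM to 12000 nM.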

Compound 3, half-maximal inhibitory concentration: 3500 nM
Compound 3: the middle estimate sits 1.1-fold (0.06 log units) above what was measured; low and high end bracket the measured number.
By their numbers in this assay, from the lowest: compounds 2, 3 and 1 (each within the scatter of the next, the first and the last beyond it).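

In this assay the exchange of nitro for trifluoromethoxy on an aromatic carbon, para to a large group, gives a 1.9-fold lower number from compound 1 to compound 3 (0.28 log units; within the scatter) and so stays within the usual scatter of repeated measurements. Among these compounds, this is the first single-change reading at this position, which the two earlier compounds could not provide because they differ in more than one place, and it shows that replacing a group of 3 heavy atoms with one of 5 heavy atoms here leaves the read-out indistinguishable from that of compound 1. The data shown offer no explanation for this result.

What the compounds shown leave open is how an amine, a carboxylic acid, a nitrile or a simple methyl group on this same aromatic carbon would read, and so whether any group here can move the value beyond the scatter. Among the compounds shown here, it also remains open whether the exchange of nitro for trifluoromethoxy would read the same on a different core, such as the one carried by compound 2.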